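A Fluorophenyl Gives Way to an Aminophenyl

The source may hold more compounds than are shown below. What is called first, only, known or untested is meant among the compounds shown, and "the series" means these compounds.

Compound 2 `COc1cc(-c2cccc3nc(-c4cccc(F)c4)oc23)cc(OC)c1OC`: in a functional assay on MCF7 cells (Homo sapiens) for antiproliferative activity, read by MTT assay, with a stated time of 48 h (a lower number here means a stronger inhibitor, a higher number a weaker inhibitor), compound 2 gives > 25000 nM, a limit of the assay.
Compound 1 `COc1ccc(-c2nc3cccc(-c4cc(OC)c(OC)c(OC)c4)c3o2)cc1`: compound 1 gives > 25000 nM, also a limit.
Compound 3 `COc1cc(-c2cccc3nc(-c4ccc(C)cc4)oc23)cc(OC)c1OC`: compound 3 gives > 25000 nM, again a limit.

Within the data shown here, compound 2 therefore stands at the limit, as do the other two compounds, because the limit of > 25000 nM in this assay, at which 3 of the 3 values shown sit, describes every value so far. Compound 4 `COc1cc(-c2cccc3nc(-c4ccc(N)cc4)oc23)cc(OC)c1OC` differs from compound 2 in one place: 4-aminophenyl in place of 3-fluorophenyl on an aromatic carbon. The measured steps at this position, a step that the two limits leave unreadable from compound 2 to compound 3 and a step that the two limits leave unreadable from compound 1 to compound 2, give no readable size, so they set no expectation of direction or scale. The step of an at least 1.6-fold lower number from compound 2 to compound 4 (0.22 log units; that floor lies within the scatter) is only an estimate, leaning toward little change. Compound 4 is thus expected to give 15000 nM, within 2000 nM to 60000 nM, with a real chance of another limit.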

Compound 4, half-maximal inhibitory concentration: > 25000 nM
Compound 4 ended at the assay's limit; the forecaster's own chance of this, stated with the estimate: 55%; middle value at least 1.6-fold (0.22 log units) from the limit.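

No step between compound 4 and compound 1, compound 2 or compound 3 can be read, because all four sit at the same limit: the limit of > 25000 nM in this assay, at which 4 of the 4 values shown sit.

The compounds shown leave open which change to the shared core, if any, would give a measured number instead of a limit.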